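Swapping the Amide Heteroaryl: Compound 3 to Compound 4

This account rests on a few compounds, and the source may have more. Where it says the series, first, only, none or still open, it means among the compounds named here.

Measured compounds:
compound 1, `COc1cc(N(C)C)c(NC(=O)c2ccncc2)cc1Nc1nccc(-c2cn(C)c3ccccc23)n1`, gives 9000 nM
compound 2, `COc1ccc(C(=O)Nc2cc(Nc3nccc(-c4cn(C)c5ccccc45)n3)c(OC)cc2N(C)C)nc1`, gives 5150 nM
compound 3, `COc1cc(N(C)C)c(NC(=O)c2ncccn2)cc1Nc1nccc(-c2cn(C)c3ccccc23)n1`, gives 8640 nM

In a functional assay on A549 cells (Homo sapiens) for antiproliferative activity, read by MTT assay, with a stated time of 72 h (on this read-out higher numbers stand for weaker inhibition and lower numbers for stronger inhibition), the three measured compounds share a common core and differ only in the heteroaryl group on the carbonyl carbon of the amide. Compound 3 sits second highest of the three numbers; its nearest neighbour is compound 1 and its furthest is compound 2, and both of those gaps fall within the scatter. The steps of a 1.7-fold lower number from compound 1 to compound 2 (0.24 log units; within the scatter), a 1.0-fold lower number from compound 1 to compound 3 (0.02 log units; within the scatter) and a 1.7-fold higher number from compound 2 to compound 3 (0.22 log units; within the scatter) are all within the scatter, so none of the three heteroaryl exchanges seen so far has shifted this assay beyond noise.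

Compound 4, `COc1cc(N(C)C)c(NC(=O)c2ccnc(Cl)n2)cc1Nc1nccc(-c2cn(C)c3ccccc23)n1`, carries the next exchange at the same position: 2-chloropyrimidin-4-yl in place of pyrimidin-2-yl on a carbonyl carbon. Every prior change at this carbonyl carbon was silent, so the same is expected here; the step from compound 3 to compound 4 is estimated as a 1.1-fold lower number from compound 3 to compound 4 (0.03 log units; within the scatter), with no direction beyond the scatter. Compound 4 is therefore expected to give about 8000 nM, in a range from 3000 nM to 22000 nM.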

Compound 4, half-maximal inhibitory concentration: 2840 nM
Estimate against measurement, compound 4: 2.8-fold (0.45 log units) above; measured number below the stated range.
By their numbers in this assay, from the lowest: compounds 4, 2, 3 and 1 (each within the scatter of the next, the first and the last beyond it).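

In this assay, for the compounds shown here, the amide heteroaryl position is no longer silent: the exchange to 2-chloropyrimidin-4-yl gives a 3.0-fold lower number from compound 3 to compound 4 (0.48 log units; beyond the scatter) and also a 3.2-fold lower number from compound 1 to compound 4 (0.50 log units; beyond the scatter) as the first steps at this carbonyl carbon beyond the scatter, both modest. The gain is not clear against every earlier group, however, since the comparison with 5-methoxypyridin-2-yl gives a 1.8-fold lower number from compound 2 to compound 4 (0.26 log units; within the scatter) and leaves those two groups unseparated. Nothing available here explains the step. 

The exchange adds a chlorine and also changes the ring from pyrimidin-2-yl to a pyrimidin-4-yl group, and the compounds shown do not separate these two changes. A pyrimidin-4-yl group without the chlorine, or one carrying an amine or a methoxy group instead, would show which of them goes with the lower number.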